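Replacing a methoxyphenyl amide with a trifluoromethylphenyl amide

A few compounds are considered here, and "the series" means these few. Any claim that something is new, unique, unknown or untested is made for them only; others in the source may bear on it.

Compound 1 `O=C(CSc1nc(Nc2ccccc2)c2ccccc2n1)Nc1cccc(F)c1` and compound 2 `COc1cccc(NC(=O)CSc2nc(Nc3ccccc3)c3ccccc3n2)c1` share a core and differ only on the outer ring of the amide. In a functional assay on MDA-MB-231 cells (Homo sapiens) for inhibition, read by MTT assay, with a stated time of 72 h (a lower number here means a stronger inhibitor, a higher number a weaker inhibitor), compound 1 reports only a limit, > 50000 nM. In this assay, among the compounds with values here, compound 2 gives 21700 nM, the only number among the two values shown. Within the data shown here, the change an at least 2.3-fold lower number from compound 1 to compound 2 (0.36 log units; beyond the scatter) is the single measured step. Compound 3 `O=C(CSc1nc(Nc2ccccc2)c2ccccc2n1)Nc1ccc(C(F)(F)F)cc1` changes the same ring again: 4-(trifluoromethyl)phenyl in place of 3-methoxyphenyl on an amide-type nitrogen. Among the measured compounds shown here, the only related step, an at least 2.3-fold lower number from compound 1 to compound 2 (0.36 log units; beyond the scatter), went toward stronger inhibition when methoxy entered, and bears on compound 3 only loosely. The step of a 2.1-fold higher number from compound 2 to compound 3 (0.32 log units; beyond the scatter) is therefore expected to run back toward weaker inhibition, and compound 3 is estimated at 45000 nM, between 18000 nM and 110000 nM.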

Compound 3, half-maximal inhibitory concentration: 11100 nM
Beside the measured number, compound 3's estimate is 4.1-fold (0.61 log units) above it; the whole stated range lies above it.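

In this assay, 4-(trifluoromethyl)phenyl in place of 3-methoxyphenyl on the amide-type nitrogen gives a 2.0-fold lower number from compound 2 to compound 3 (0.29 log units; within the scatter), so these two rings cannot be told apart here. In place of 3-fluorophenyl, the same group gives an at least 4.5-fold lower number from compound 1 to compound 3 (0.65 log units; beyond the scatter), so both the methoxy ring and the trifluoromethyl ring stand apart from the fluoro ring. Compound 1 gives only a limit of the assay, so that step is a bound and not an exact size: the limit of > 50000 nM in this assay, at which 1 of the 3 values shown sits.

From the compounds shown here alone, compound 2 and compound 3 differ in both the group and its place on the ring, so which of the two matters stays open. Going by these compounds, the effect of an amine or a carboxylic acid on this ring also stays open.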